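Replacing the Chlorophenyl Arm with a Thiazole

A few compounds are considered here, and "the series" means these few. Any claim that something is new, unique, unknown or untested is made for them only; others in the source may bear on it.

Compound 1, `C=C1CC[C@@H]2[C@](C)(CO)[C@H](O)CC[C@@]2(C)[C@@H]1CC=O`: > 30000 nM (a limit of the assay).
Compound 2, `C=C1CC[C@@H]2[C@](C)(CNCc3ccc(OC)c(OC)c3)[C@H](O)CC[C@@]2(C)[C@@H]1/C=C/C1=CCOC1=O`: 3740 nM.
Compound 3, `C=C1CC[C@@H]2[C@](C)(CNCc3ccc(Cl)cc3)[C@H](O)CC[C@@]2(C)[C@@H]1/C=C/C1=CCOC1=O`: 420 nM.

In a functional assay on BMMC cells (Mus musculus, strain C57BL/6) for inhibition, with stated times of 5 days and 48 h (on this read-out higher numbers stand for weaker inhibition and lower numbers for stronger inhibition), compound 3 gives 420 nM, the lowest of the two numbers shown; compound 2 gives 3740 nM. For compound 1 the assay reports only a limit, > 30000 nM. Compound 4, `C=C1CC[C@@H]2[C@](C)(CNCc3nccs3)[C@H](O)CC[C@@]2(C)[C@@H]1/C=C/C1=CCOC1=O`, differs from compound 3 by 1,3-thiazol-2-yl in place of 4-chlorophenyl on a saturated chain carbon bound to an amine nitrogen. Going by the values given here, the only measured step touching this position is an 8.9-fold lower number from compound 2 to compound 3 (0.95 log units; beyond the scatter), which shows that the group on that carbon moves the number well beyond the scatter. Among the compounds with values here, since no measured step covers the thiazole itself, the direction is uncertain, but a higher number than compound 3 is expected, with the step of a 4.8-fold higher number from compound 3 to compound 4 (0.68 log units; beyond the scatter). Compound 4 is therefore estimated at 2000 nM, within 500 nM to 8000 nM.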

Compound 4, half-maximal inhibitory concentration: 700 nM
Beside the measured number, compound 4's estimate is 2.9-fold (0.46 log units) above it, within the range that was stated.
By their numbers in this assay, from the lowest: compounds 3 and 4 (each within the scatter of the next); then compound 2. At a limit, above all of these: compound 1.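

In this assay the change to 1,3-thiazol-2-yl gives a 1.7-fold higher number from compound 3 to compound 4 (0.22 log units; within the scatter) so on this saturated chain carbon a five-membered aromatic ring with 2 hetero atoms reads the same as 4-chlorophenyl, and a six-membered aromatic ring of carbon only is not needed to keep the number. There is also a 5.3-fold lower number from compound 2 to compound 4 (0.73 log units; beyond the scatter) and so, of the three groups compared here, 3,4-dimethoxyphenyl alone stands apart. Nothing measured here accounts for this. On these data alone, it remains open whether a thiazole carrying an amine or a carboxylic acid would hold the number. A longer chain between the amine nitrogen and the ring is equally untested in what is shown.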